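Exchanging a methyl for a hydroxy on the shared core

The source may hold more compounds than are shown below. What is called first, only, known or untested is meant among the compounds shown, and "the series" means these compounds.

Measured compounds:
- Compound 1, `Cc1c(OCCCCOc2cccc(C(=O)O)c2)ccc(C(=O)CC(C)C)c1C`, gives 18.3%
- Compound 2, `Cc1c(OCCCCOc2ccc(C(=O)O)c(Cl)c2)ccc(C(=O)CC(C)C)c1C`, gives 12%
- Compound 3, `Cc1c(OCCCCOc2ccccc2C(=O)O)ccc(C(=O)CC(C)C)c1C`, gives 30.7%

These numbers come from an assay on HEK293 cells for positive allosteric modulation of metabotropic glutamate receptor 3 (Rattus norvegicus), read by thallium flux, with a stated time of 2.5 min; on this read-out higher numbers stand for larger maximal responses and lower numbers for smaller maximal responses. Compound 1 stands second highest of the three: compound 2 lies a number 6.3 percentage points lower from compound 1 to compound 2 (within the scatter), and compound 3 lies a number 12.4 percentage points higher from compound 1 to compound 3 (beyond the scatter). Compound 2 and compound 3 differ by a number 18.7 percentage points higher from compound 2 to compound 3 (beyond the scatter).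

Compound 4 is `Cc1c(OCCCCOc2cccc(C(=O)O)c2)ccc(C(=O)CC(C)C)c1O`. Set against compound 1 it differs by hydroxy in place of methyl on an aromatic carbon. Going by the values given here, every measured step so far concerns the carboxyphenyl end of the chain, whereas this change sits on the shared core. Among the compounds with values here, no measured step bears on it, so there is nothing to point in either direction. The expectation is therefore that compound 4 moves from compound 1 by about a number 0.3 percentage points lower from compound 1 to compound 4 (within the scatter), which is within the scatter. Compound 4 is estimated at 18%, with a range from 6% to 32%.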

Compound 4, largest response reached (reported as percent of maximum), in percent of the reference or control that the assay uses: 69.9%
The estimate for compound 4 lay 51.9 percentage points below the measured number; the measured number lies above the stated range.
By their numbers in this assay, from the lowest: compounds 2 and 1 (each within the scatter of the next); then compound 3; then compound 4.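

On the shared core, hydroxy in place of methyl gives a number 51.6 percentage points higher from compound 1 to compound 4 (beyond the scatter) in this assay and so shows that this position, ortho to an isobutylcarbonyl group, strongly affects the maximal response. The widest step at the carboxyphenyl end of the chain is a number 18.7 percentage points higher from compound 2 to compound 3 (beyond the scatter) and the exchange of one heavy atom on the core clearly exceeds it, even though that exchange only replaces a methyl with a group carrying a hydrogen-bond donor and acceptor. Nothing available here accounts for the size of this rise.

Going by these compounds, it remains open whether an amine or a methoxy at this position would give a similar response, or whether the gain depends on the hydroxy itself. On these data alone, it is also open whether the same exchange would raise the response when the chain ends in the 2-carboxyphenyl group of compound 3.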